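Methylamino for methoxy in a fused-ring nucleoside series

A few compounds are considered here, and "the series" means these few. Any claim that something is new, unique, unknown or untested is made for them only; others in the source may bear on it.

In an ADME assay on MRC5 cells (Homo sapiens), read by MTT assay, with a stated time of 72 h (on this read-out higher numbers stand for weaker inhibition and lower numbers for stronger inhibition), compound 2 `COc1ncnc2c1c(I)cn2[C@@H]1O[C@H](CO)[C@@H](O)[C@H]1O` gives 63000 nM. In this assay compound 1 `CNc1ncnc2c1c(I)cn2[C@@H]1O[C@H](CO)[C@@H](O)[C@H]1O` gives > 100000 nM, which is a limit of the assay and not a number (the limit of > 100000 nM in this assay, at which 1 of the 3 values shown sits). The change methylamino in place of methoxy on an aromatic carbon thus made a step of an at least 1.5-fold higher number from compound 2 to compound 1 (0.20 log units; that floor lies within the scatter). Compound 3 `COc1ncnc2c1c(-c1cc3ccccc3o1)cn2[C@@H]1O[C@H](CO)[C@@H](O)[C@H]1O` gives 65600 nM in this assay; its core differs from that of compound 2 by 1-benzofuran-2-yl in place of iodo on an aromatic carbon, a step of a 1.0-fold higher number from compound 2 to compound 3 (0.02 log units; within the scatter). Compound 4 `CNc1ncnc2c1c(-c1cc3ccccc3o1)cn2[C@@H]1O[C@H](CO)[C@@H](O)[C@H]1O` is not yet measured; it differs from compound 3 by methylamino in place of methoxy on an aromatic carbon, the same change, at the same place, as that seen between compound 2 and compound 1. In this assay compound 4 is expected to give about 130000 nM, within 50000 nM to 350000 nM. For compound 4 the expected step is a 2.0-fold higher number from compound 3 to compound 4 (0.30 log units; within the scatter), resting on the earlier step of an at least 1.5-fold higher number from compound 2 to compound 1 (0.20 log units; that floor lies within the scatter).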

Compound 4, half-maximal inhibitory concentration: 75300 nM
Estimate against measurement, compound 4: 1.7-fold (0.24 log units) above, within the range that was stated.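

In this assay, methylamino in place of methoxy on an aromatic carbon makes a step of a 1.1-fold higher number from compound 3 to compound 4 (0.06 log units; within the scatter), while 1-benzofuran-2-yl in place of iodo on an aromatic carbon makes a step of an at least 1.3-fold lower number from compound 1 to compound 4 (0.12 log units; that floor lies within the scatter). Compound 1 gives > 100000 nM, which is a limit of the assay and not a number. The methylamino change stays within the scatter on the core of compound 3, but its carry-over from one core to the other is shown neither to hold nor to fail: the same change on two cores in this assay, an at least 1.5-fold higher number (0.20 log units; that floor lies within the scatter) from compound 2 to compound 1 and a 1.1-fold higher number (0.06 log units; within the scatter) from compound 3 to compound 4; the limit leaves it open whether they differ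

Still open, as far as these compounds go, is whether an amino or dimethylamino group in place of methoxy would give a step beyond the scatter on either core. Also open, from the compounds shown here alone, is how a phenyl group in place of iodo would read.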